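Adding a Second Fluoro Group to Compound 2

The source may hold more compounds than are shown below. What is called first, only, known or untested is meant among the compounds shown, and "the series" means these compounds.

Compound 1 `O=C(CC(c1ccc(F)cc1)C(C(=O)Nc1ccccn1)C(=O)Nc1ccccn1)c1ccccc1` gives 20900 nM
Compound 2 `O=C(CC(c1ccccc1)C(C(=O)Nc1ccccn1)C(=O)Nc1ccccn1)c1ccc(F)cc1` gives "not active" (no number reported)

In a functional assay on MCF7 cells (Homo sapiens) for inhibition, read by MTT assay, with a stated time of 48 h (a higher number here means a weaker inhibitor, a lower number a stronger inhibitor), compound 2 is recorded as "not active" (no number reported) and so has no single number to stand on. Compound 3 `O=C(CC(c1ccc(F)cc1)C(C(=O)Nc1ccccn1)C(=O)Nc1ccccn1)c1ccc(F)cc1` keeps the shared core of compound 2 and makes one change: fluoro in place of hydrogen on an aromatic carbon, turning a phenyl into a 4-fluorophenyl. Going by the values given here, no measured step shows what this change does, so its size can only be expected. A modest shift toward stronger inhibition is expected, from no measurable effect to weak but measurable inhibition, though compound 3 could also come back without a number. The nearest measured guide is compound 1 at 20900 nM in this assay, and the estimate stays close to it. Compound 3 is expected near 25000 nM in an estimated range from 8000 nM to 80000 nM in this test.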

Compound 3, half-maximal inhibitory concentration: 23300 nM
Compound 3: middle estimate off by 1.1-fold (0.03 log units), on the high side; the measured number falls inside the stated range.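

In this assay, going by these compounds alone, compound 2 has no number, whereas compound 3 gives 23300 nM, so the step between them cannot be read as a size; the printed values show only that a number is reported once the 4-fluorophenyl replaces the phenyl. The same kind of swap, made in a different place on the shared core, can be read, and it gives a 1.1-fold higher number from compound 1 to compound 3 (0.05 log units; within the scatter), so a fluoro there leaves the two compounds indistinguishable in this test. Nothing available explains either result.

Open, going by these compounds, is how a chlorine atom, a methoxy group or an amine in place of this fluoro would read in this assay. Also open, on these data alone, is whether any such group would bring the number far below that of compound 3.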